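Methyl on the urea nitrogen: compound 3 to compound 4

This account rests on a few compounds, and the source may have more. Where it says the series, first, only, none or still open, it means among the compounds named here.

Working notes. The three measured compounds share one core and differ only in the group on the carbonyl carbon. Compound 1 `COc1ccccc1NC(=O)N1CCC(c2nc(-c3ccc4ccccc4n3)no2)CC1` gives 410 nM in a functional assay on Shh Light II cells (Mus musculus) for inhibition, read by a luciferase reporter; on this read-out higher numbers stand for weaker inhibition and lower numbers for stronger inhibition; compound 2 `N#Cc1ccccc1NC(=O)N1CCC(c2nc(-c3ccc4ccccc4n3)no2)CC1` gives 190 nM in this assay; compound 3 `O=C(Nc1ccccc1Cl)N1CCC(c2nc(-c3ccc4ccccc4n3)no2)CC1` gives 510 nM in this assay. Compound 3 stands at the highest of the three numbers, yet its separation from compound 1 is within the scatter (a 1.2-fold higher number from compound 1 to compound 3 (0.09 log units; within the scatter)), so no order between those two can be read; only compound 2 is clearly apart from it (a 2.7-fold higher number from compound 2 to compound 3 (0.43 log units; beyond the scatter)), consistent with a 2.2-fold lower number from compound 1 to compound 2 (0.33 log units; beyond the scatter).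

Compound 4 `COc1ccccc1N(C)C(=O)N1CCC(c2nc(-c3ccc4ccccc4n3)no2)CC1` differs from compound 3 as follows: (2-methoxyphenyl)(methyl)amino in place of (2-chlorophenyl)amino on a carbonyl carbon. Two things change together. Methoxy returns in place of chloro, and for that the only precedent is a 1.2-fold higher number from compound 1 to compound 3 (0.09 log units; within the scatter), which read backwards predicts no step beyond the scatter. For the measured compounds named here, the methyl on the amide nitrogen, replacing the hydrogen-bond donor counted above, has no precedent among the measured compounds, so its contribution in this assay is unknown.

Expectation for compound 4 in this assay: the number is estimated at 1000 nM, set somewhat above compound 3 with a wide range from 350 nM to 3500 nM to cover the unprecedented change. The expected step is therefore a 2.0-fold higher number from compound 3 to compound 4 (0.29 log units; within the scatter), a modest rise, not firmly beyond the scatter.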

Compound 4, half-maximal inhibitory concentration: 3100 nM
Compound 4: the middle estimate sits 3.1-fold (0.49 log units) below what was measured, and the stated range covers the measured number.
By their numbers in this assay, from the lowest: compound 2; then compounds 1 and 3 (each within the scatter of the next); then compound 4.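

In this assay, for the compounds shown here, the one clean reading of methyl in place of hydrogen on the amide-type nitrogen is a 7.6-fold higher number from compound 1 to compound 4 (0.88 log units; beyond the scatter), whereas the largest step among the earlier compounds, all of which keep the amide hydrogen, was a 2.7-fold higher number from compound 2 to compound 3 (0.43 log units; beyond the scatter). Going by these compounds alone, the other two steps, a 6.1-fold higher number from compound 3 to compound 4 (0.78 log units; beyond the scatter) and a 16-fold higher number from compound 2 to compound 4 (1.21 log units; beyond the scatter), carry a change of ring substituent along with the methyl, yet they point the same way, and the step with the nitrile as its starting point is the largest so far. In these compounds, then, the amide nitrogen is a more sensitive place than the ring substituent, although nothing available here gives a reason for the rise.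

Going by these compounds, it remains open whether the rise follows from losing the amide hydrogen or from the added methyl itself, which an ethyl on that nitrogen, or an oxygen in its place, would help to separate. On these data alone, it is equally open whether the same methyl costs as much with chloro or nitrile on the ring as it does with methoxy.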